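Piperazine amide series: cytotoxicity read-out ahead of compound 4

The compounds below may be only part of what the source reports. "The series", "measured", "known", "first", "only" and "open" are said of these compounds alone.

Of the compounds shown here, three sharing one core have been measured in an ADME assay on RAW264.7 cells (Mus musculus) for cytotoxicity, read by MTT assay, with a stated time of 72 h, tested at 50 uM; on this read-out higher numbers stand for more inhibition at the one concentration tested (going by the name of the read-out) and lower numbers for less inhibition. Compound 1 `O=C(O)c1cn(C2CC2)c2cc(N3CCN(C(=O)CN4CCN(Cc5ccccc5)CC4)CC3)c(F)cc2c1=O` gives 15.5%. Compound 2 `O=C(O)c1cn(C2CC2)c2cc(N3CCN(C(=O)CN4CCN(c5ccccc5Cl)CC4)CC3)c(F)cc2c1=O` gives 14.9%. Compound 3 `CCN1CCN(CC(=O)N2CCN(c3cc4c(cc3F)c(=O)c(C(=O)O)cn4C3CC3)CC2)CC1` gives 13.3%. Compound 3 sits with the other two: a number 2.2 percentage points lower from compound 1 to compound 3 (within the scatter) and a number 1.6 percentage points lower from compound 2 to compound 3 (within the scatter), so all three numbers share one band.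

Compound 4 `O=C(O)c1cn(C2CC2)c2cc(N3CCN(C(=O)CN4CCN(c5ncccn5)CC4)CC3)c(F)cc2c1=O` differs from compound 3 by pyrimidin-2-yl in place of ethyl on an amine nitrogen in a ring. For the measured compounds named here, the steps that bear on this place are a number 1.6 percentage points lower from compound 2 to compound 3 (within the scatter) and a number 0.6 percentage points lower from compound 1 to compound 2 (within the scatter), both at the same amine nitrogen and both within the scatter. No step beyond the scatter is therefore expected in this assay ; the estimated step is a number 1.2 percentage points higher from compound 3 to compound 4 (within the scatter).

Compound 4 is expected to give 14.5%, within 5% to 25%.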

Compound 4, a percentage reported as inhibition, at one concentration (the size of the read-out at that concentration, not a potency): 11%
Compound 4: the middle estimate sits 3.5 percentage points above what was measured, within the range that was stated.
By their numbers in this assay, from the lowest: compounds 4, 3, 2 and 1 (each within the scatter of the next).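

At this amine nitrogen in a ring, pyrimidin-2-yl brings in an aromatic ring with 2 hetero atoms and 2 hydrogen-bond acceptors, yet this assay shows only a number 2.3 percentage points lower from compound 3 to compound 4 (within the scatter) and a number 3.9 percentage points lower from compound 2 to compound 4 (within the scatter) and a number 4.5 percentage points lower from compound 1 to compound 4 (within the scatter). Ethyl, benzyl, 2-chlorophenyl and pyrimidin-2-yl therefore share one band at this place. No supporting data bear on this result.

Still open, going by these compounds, is whether a primary amine or a longer chain ending in a carboxylic acid on this nitrogen would give a step beyond the scatter.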